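A Hydroxyphenyl Rearrangement: From Compound 2 to Compound 4

This account rests on a few compounds, and the source may have more. Where it says the series, first, only, none or still open, it means among the compounds named here.

Three compounds with a shared core were examined in a functional assay on HCT-15 cells (Homo sapiens) for cytotoxicity, read by CCK-8 assay and cell counting, with a stated time of 2 days; on this read-out lower numbers stand for stronger inhibition and higher numbers for weaker inhibition. Compound 2 `Oc1ccc(-c2cc(-c3ccccc3)nc(-c3ccccc3Cl)c2)cc1` gives 4990 nM. Compound 1 `Oc1ccc(-c2cc(-c3ccccn3)nc(-c3ccccc3Cl)c2)cc1` gives "not determined" (no result reported) in this assay, so no result is reported for it. Compound 3 `Oc1ccc(-c2cc(-c3ccncc3)nc(-c3ccccc3Cl)c2)cc1` likewise gives "not determined" (no result reported) in this assay, so no result is reported for it either. Compound 2 therefore stands as the only compound with a number, and there is no second value among these three against which it could be placed.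

Compound 4 `Oc1cccc(-c2cc(-c3ccccc3)nc(-c3ccccc3Cl)c2)c1` has not yet been measured in this assay. The change from compound 2 is 3-hydroxyphenyl in place of 4-hydroxyphenyl on an aromatic carbon; the two compounds hold the same atoms joined differently. Among the measured compounds shown here, no step between measured compounds shows what such a change does here, so any expectation rests only on compound 2 at 4990 nM. The step is expected to be a 1.4-fold higher number from compound 2 to compound 4 (0.15 log units; within the scatter), a modest weakening that may well stay within the scatter of repeated measurements. Compound 4 is accordingly estimated at 7000 nM, with a range from 2500 nM to 25000 nM.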

Compound 4, half-maximal inhibitory concentration: 2930 nM
For compound 4 the middle estimate is 2.4-fold (0.38 log units) above the measured one; low and high end bracket the measured number.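

In this assay, 3-hydroxyphenyl in place of 4-hydroxyphenyl, at the place opposite the ring nitrogen, gives a 1.7-fold lower number from compound 2 to compound 4 (0.23 log units; within the scatter), and this step lies within the usual scatter of repeated measurements. Among the compounds shown here, it is the first step between measured compounds, and it shows that this read-out does not separate the two arrangements of the hydroxyl group at this position on the shared core. Nothing available bears on why the two compounds read alike.

The compounds shown leave open what an amine or a carboxylic acid would do in place of the hydroxyl group on this aromatic ring. Steps from compound 1 and compound 3 to the other compounds cannot be read, so the part played by the phenyl group in compound 2 and compound 4 also remains open.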